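A few compounds are considered here, and "the series" means these few. Any claim that something is new, unique, unknown or untested is made for them only; others in the source may bear on it.

Measured compounds:
Compound 1, `CC(C)S(=O)(=O)c1ccccc1NCC1=NCCN1`: < 10000 nM — a limit of the assay, not a number
Compound 2, `CS(=O)(=O)c1c(F)cccc1NCC1=NCCN1`: 501 nM

In a functional assay on CHO cells for agonist activity at Alpha-2C adrenergic receptor (Homo sapiens) (on this read-out lower numbers stand for an effect already at smaller amounts and higher numbers for an effect only at larger amounts of compound), compound 1 stands only at a limit of the assay, (the limit of < 10000 nM in this assay, at which 1 of the 2 values shown sits), so no number is known for it. Among the compounds with values here, compound 2 is the one compound with a measured number in this assay. Compound 3, `CCS(=O)(=O)c1ccccc1NCC1=NCCN1`, has not yet been measured there. It differs from compound 1 in a single place: hydrogen in place of methyl on a saturated chain carbon bound to a saturated chain carbon and a sulfonyl sulfur. Within the data shown here, no step between two measured compounds covers this change, so the size of the step can only be set from where compound 1 stands. With compound 1 sitting at its limit, compound 3 is expected to come out within that limit, with a step that the limit leaves unreadable from compound 1 to compound 3 toward an effect at smaller amounts, though a result that again reports only a limit cannot be ruled out. For compound 3 the expected value in this assay is 1500 nM, with a range from 300 nM to 8000 nM.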

Compound 3, half-maximal effective concentration: 5010 nM
Beside the measured number, compound 3's estimate is 3.3-fold (0.52 log units) below it; low and high end bracket the measured number.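

Compound 1 gives < 10000 nM in this assay, a limit and not a number, so no step from it to compound 3 can be read: the limit of < 10000 nM in this assay, at which 1 of the 3 values shown sits.

The compounds shown leave open how far the change from isopropylsulfonyl to ethylsulfonyl moves the value in this assay.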